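This account rests on a few compounds, and the source may have more. Where it says the series, first, only, none or still open, it means among the compounds named here.

In an ADME assay on liver (Mesocricetus auratus) for metabolic stability, using microsomes (a higher number here means faster removal of the compound, a lower number slower removal), compound 2 `O=C(Nc1cc(-c2ccccn2)n[nH]1)N1CCC(c2ccc(F)cc2)CC1` gives 272 mL.min-1.g-1, the only number shown for the series so far. Compound 1 `O=C(Nc1[nH]nc(-c2ccccn2)c1C1CC1)c1ccccc1F` stands at > 100 mL.min-1.g-1, which is a limit of the assay and not a number. Compound 3 `O=C(Nc1[nH]nc(-c2ccccn2)c1C1CC1)c1c(Cl)cccc1Cl` stands at > 100 mL.min-1.g-1, which is also a limit. The overall picture in this assay is therefore (the limit of > 100 mL.min-1.g-1 in this assay, at which 2 of the 3 values shown sit).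

Compound 4 `O=C(Nc1cc(-c2ccccn2)n[nH]1)N1CCC(c2cccc(Cl)c2)CC1` has 3-chlorophenyl in place of 4-fluorophenyl on a saturated ring carbon of the six-membered non-aromatic ring with 1 nitrogen, three ring bonds from the ring nitrogen. The change from compound 2 is as follows: 3-chlorophenyl in place of 4-fluorophenyl on a saturated ring carbon.

Among the compounds with values here, only one measured step is available, a step that the two limits leave unreadable from compound 1 to compound 3. It puts 2,6-dichlorophenyl in place of 2-fluorophenyl on a carbonyl carbon, so it lies at a different place and has no size to carry over. Within the data shown here, no measured step bears directly on the change to compound 4. The expectation therefore rests on compound 2 at 272 mL.min-1.g-1, and no step beyond the scatter is expected in this assay.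

The estimated change is a 1.0-fold lower number from compound 2 to compound 4 (0.00 log units; within the scatter). For compound 4 the expected value is 270 mL.min-1.g-1, with an estimated range from 120 mL.min-1.g-1 to 600 mL.min-1.g-1.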

Compound 4, intrinsic clearance in microsomes: 63.5 mL.min-1.g-1
Compound 4: the middle estimate sits 4.3-fold (0.63 log units) above what was measured; measured number outside the range, below it.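

In this assay, within the data shown here, 3-chlorophenyl in place of 4-fluorophenyl on a saturated ring carbon gives a 4.3-fold lower number from compound 2 to compound 4 (0.63 log units; beyond the scatter), the first readable step. The two groups match in heavy-atom count, in their six-membered aromatic ring of carbon only, in having no hydrogen-bond donors or acceptors and in having no net charge, so they differ only in the halogen and in where it sits on the phenyl ring, and that difference alone moves this read-out beyond the scatter. The other step in the series cannot be read, and the values of compound 1 and compound 3 are limits of the assay and not numbers, so this position remains the only one with a readable size: the limit of > 100 mL.min-1.g-1 in this assay, at which 2 of the 4 values shown sit.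

Nothing measured here gives a cause for the step, and its two parts, the change of halogen and the change of its place, remain unseparated. A 4-chlorophenyl or 3-fluorophenyl group at this position would separate those two parts, and an unsubstituted phenyl or a methoxyphenyl group would show whether a halogen is needed for the step at all.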